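Swapping bromine for iodine on a cytotoxicity-limited scaffold

A few compounds are considered here, and "the series" means these few. Any claim that something is new, unique, unknown or untested is made for them only; others in the source may bear on it.

Compound 1, `COc1ccc(/C=C2\CC[C@H]3C(C)(C)CCC[C@]3(C)[C@H]2CCC(C)CC(=O)O)cc1OC`: > 200000 nM
Compound 2, `CC(CC[C@H]1/C(=C/c2ccc(Br)cc2)CC[C@H]2C(C)(C)CCC[C@]12C)CC(=O)O`: > 200000 nM

In an ADME assay on HUVEC cells (Homo sapiens) for cytotoxicity, read by MTT assay, with a stated time of 72 h (on this read-out lower numbers stand for stronger inhibition and higher numbers for weaker inhibition), compound 1 reaches only a limit of the assay, > 200000 nM. Compound 2 likewise stops at a limit, > 200000 nM. The step that the two limits leave unreadable from compound 1 to compound 2 thus cannot be sized, since both numbers sit at the limit of > 200000 nM in this assay, at which 2 of the 2 values shown sit. Compound 3, `CC(CC[C@H]1/C(=C/c2ccc(I)cc2)CC[C@H]2C(C)(C)CCC[C@]12C)CC(=O)O`, differs from compound 2 by iodo in place of bromo on an aromatic carbon. Among the measured compounds shown here, no measured step bears on this swap, and the only measured step is unreadable. Compound 3 is therefore expected to remain at the limit, with an estimated 200000 nM (range 80000 nM to 500000 nM). The expected step of a number no higher from compound 2 to compound 3 (the limit leaves the size open) should lie within the scatter.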

Compound 3, half-maximal inhibitory concentration: 100000 nM
Compound 3: the middle estimate sits 2.0-fold (0.30 log units) above what was measured; low and high end bracket the measured number.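

In this assay, compound 3 is the only compound shown with a number rather than a limit: the limit of > 200000 nM in this assay, at which 2 of the 3 values shown sit. Iodo in place of bromo gives an at least 2.0-fold lower number from compound 2 to compound 3 (0.30 log units; that floor lies within the scatter), and 4-iodophenyl in place of 3,4-dimethoxyphenyl gives an at least 2.0-fold lower number from compound 1 to compound 3 (0.30 log units; that floor lies within the scatter). Both are only floors within the scatter, so a real change at this aromatic carbon is possible but not established.

The step between the two limits cannot be read. On these data alone, it remains open whether chloro or trifluoromethyl on the same aromatic carbon would give a number or stay at the limit.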